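Rotarod series: amino in place of butyl on the chain

The source may hold more compounds than are shown below. What is called first, only, known or untested is meant among the compounds shown, and "the series" means these compounds.

compound 1 `CCCCCC(=O)NCC(=O)N(C)c1ccc(Cl)cc1C(=O)c1ccccc1Cl` — 90 mg/kg
compound 2 `NC(C(=O)NCC(=O)Nc1ccc(Cl)cc1C(=O)c1ccccc1)c1ccccc1` — > 100 mg/kg

For the measured compounds named here, in a functional assay on the whole organism with Mus musculus as the target, in the rotarod test (a lower number here means that less compound is needed, a higher number that more compound is needed for the effect), compound 1 gives 90 mg/kg, the only number in the set. For compound 2 the result is a limit of the assay, > 100 mg/kg. Compound 3 `CN(C(=O)CNC(=O)CN)c1ccc(Cl)cc1C(=O)c1ccccc1Cl` differs from compound 1 by amino in place of butyl on a saturated chain carbon bound to a carbonyl carbon. Going by the values given here, no step between measured compounds is available, so the step of a 1.6-fold higher number from compound 1 to compound 3 (0.19 log units; within the scatter) is an expectation only: a rise in dose beyond the usual scatter is expected, and a limit rather than a number is likely because the limit of > 100 mg/kg in this assay, at which 1 of the 2 values shown sits, shows how near the set already sits to that edge. Compound 3 is expected at 140 mg/kg, between 50 mg/kg and 400 mg/kg.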

Compound 3, dose for half-maximal effect: 27.7 mg/kg
Compound 3: middle estimate off by 5.1-fold (0.70 log units), on the high side; the whole stated range lies above it.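

In this assay the amino group in place of butyl gives a 3.2-fold lower number from compound 1 to compound 3 (0.51 log units; beyond the scatter), so this saturated chain carbon bound to a carbonyl carbon responds to the change, and butyl is not required there for the effect. The change also yields a number rather than a limit. Compound 2 alone remains a limit of the assay: the limit of > 100 mg/kg in this assay, at which 1 of the 3 values shown sits.

Open, from the compounds shown here alone, is whether a dimethylamino group, a carboxylic acid or a longer chain ending in an amine at this place would keep the lower dose. For the compounds shown here, the role of the amino group's hydrogen-bond donor also stays unresolved, since only this one change can be read.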